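The compounds below may be only part of what the source reports. "The series", "measured", "known", "first", "only" and "open" are said of these compounds alone.

Compound 3 `SC1=NC(n2nc(-c3ccccc3)nc2-c2ccccc2)=CC(c2ccc(-c3ccccc3)cc2)N1` belongs to a set of three measured analogues built on one shared core. In a functional assay on the whole organism with Mus musculus as the target, in the maximal electroshock model, with a stated time of 4 h (a lower number here means that less compound is needed, a higher number that more compound is needed for the effect), compound 3 gives 300 mg/kg. Compound 1 `O=[N+]([O-])c1cccc(C2C=C(n3cc(-c4ccccc4)nc3-c3ccccc3)N=C(S)N2)c1` gives 300 mg/kg and compound 2 `CN(C)c1ccc(C2C=C(n3cc(-c4ccccc4)nc3-c3ccccc3)N=C(S)N2)cc1` gives 300 mg/kg; compound 3 thus stands level with both, all three within the scatter of one another. Compound 4 `COc1ccc(C2C=C(n3nc(-c4ccccc4)nc3-c3ccccc3)N=C(S)N2)c(OC)c1` differs from compound 3 by 2,4-dimethoxyphenyl in place of 4-phenylphenyl on a saturated ring carbon. Among the measured compounds shown here, the only measured step that bears on exchanging the aryl group on the saturated ring carbon is no change at the digits printed from compound 1 to compound 2 (within the scatter), which shows no movement beyond the scatter; no measured pair covers the 4-phenylphenyl to 2,4-dimethoxyphenyl exchange itself. The expected step is therefore no change at the digits printed from compound 3 to compound 4 (within the scatter), nothing beyond the scatter. Compound 4 is estimated at 300 mg/kg, with a range of 100 mg/kg to 600 mg/kg.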

Compound 4, minimum effective dose: 300 mg/kg
Estimate against measurement, compound 4: no gap at the digits printed; measured number inside the range.
By their numbers in this assay, from the lowest: compounds 1, 2, 3 and 4 (each within the scatter of the next).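

Exchanging 4-phenylphenyl for 2,4-dimethoxyphenyl on the saturated ring carbon gives no change at the digits printed from compound 3 to compound 4 (within the scatter) in this assay. The flat reading at this position now also holds for a change that removes one aromatic ring and brings in two hydrogen-bond acceptors, and on the core of compound 3, whereas the earlier step stood on the core of compound 1. No evidence at hand bears on this result. Still open, as far as these compounds go, is whether this position needs an aryl group at all, and whether an amine, a carboxylic acid or a longer alkyl chain there would read differently.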